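The source may hold more compounds than are shown below. What is called first, only, known or untested is meant among the compounds shown, and "the series" means these compounds.

Measured so far in this study:
compound 1, `COc1ccc(/C=N/NC(=O)c2cc(OC)c(OC)c(OC)c2)c(OC)c1`, gives -6.9%
compound 2, `COc1cc(C2=NN(C(C)=O)C(c3c(Cl)cccc3Cl)O2)cc(OC)c1OC`, gives -1.4%
compound 3, `COc1cc(C(=O)N/N=C/c2cccc(F)c2)cc(OC)c1OC`, gives 13.6%

In a functional assay on BGC-823 cells (Homo sapiens) for antiproliferative activity, read by MTT assay, tested at 1 uM (on this read-out lower numbers stand for a weaker effect and higher numbers for a stronger effect at the one concentration tested), compound 2 holds the second highest of these three numbers. Its nearest neighbour is compound 1, whose number lies within the scatter of compound 2, so the two cannot be told apart; compound 3 sits furthest away, with a number beyond the scatter above compound 2. Compound 4, `COc1cc(C2=NN(C(C)=O)C(c3cccc(OC)c3OC)O2)cc(OC)c1OC`, has not yet been measured. It differs from compound 2 in one place: 2,3-dimethoxyphenyl in place of 2,6-dichlorophenyl on a saturated ring carbon. Among the measured compounds shown here, no step between measured compounds that differ in a single place is known here, so nothing shows how such a swap shifts this read-out. All three measured numbers sit low, and the expected step of a number 4.4 percentage points higher from compound 2 to compound 4 (within the scatter) is small, none beyond the scatter. Compound 4 is estimated at 3%, in a range from -12% to 18%.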

Compound 4, a percentage reported as inhibition, at one concentration (the size of the read-out at that concentration, not a potency): 3.8%
The estimate for compound 4 lay 0.8 percentage points below the measured number; measured number inside the range.
By their numbers in this assay, from the lowest: compounds 1, 2, 4 and 3 (each within the scatter of the next, the first and the last beyond it).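

In this assay, among the compounds shown here, swapping the aryl group on this saturated ring carbon gives a number 5.2 percentage points higher from compound 2 to compound 4 (within the scatter), the first single-place comparison. Exchanging 2,6-dichlorophenyl, with no hydrogen-bond acceptors, for 2,3-dimethoxyphenyl, with 2, thus leaves the two compounds indistinguishable at this one concentration. Nothing measured here offers an explanation for this result. Still open, on these data alone, is whether a different group at this carbon, such as a cyclohexyl ring or a short alkyl chain, would move the number beyond the scatter. The same question applies to a phenyl ring carrying an amine or a carboxylic acid.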